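Biaryl series: dimethylphenyl in place of methoxyphenyl

The source may report more compounds than this note shows. Statements on the series, on what has been measured and on what is new or still open speak of the compounds shown alone.

For the measured compounds named here, compound 2 `COc1ccccc1-c1ccc2ncn(-c3cc(OC)c(OC)c(OC)c3)c2c1` gives 4320 nM in a functional assay on A549 cells (Homo sapiens) for antiproliferative activity, read by MTT assay, with a stated time of 72 h (a lower number here means a stronger inhibitor, a higher number a weaker inhibitor), the lowest of the two numbers known so far; its nearest neighbour is compound 1 `CCOc1ccc(-c2ccc3ncn(-c4cc(OC)c(OC)c(OC)c4)c3c2)cc1`, which gives 8550 nM, the step being a 2.0-fold lower number from compound 1 to compound 2 (0.30 log units; within the scatter). Compound 3 `COc1cc(-n2cnc3ccc(-c4ccc(C)cc4F)cc32)cc(OC)c1OC` reaches only the limit of > 10000 nM in this assay (the limit of > 10000 nM in this assay, at which 1 of the 3 values shown sits). The step of an at least 2.3-fold higher number from compound 2 to compound 3 (0.36 log units; beyond the scatter) lies beyond the scatter, whereas an at least 1.1-fold higher number from compound 1 to compound 3 (0.06 log units; that floor lies within the scatter) does not. Compound 4 `COc1cc(-n2cnc3ccc(-c4cccc(C)c4C)cc32)cc(OC)c1OC` carries 2,3-dimethylphenyl in place of 2-methoxyphenyl on an aromatic carbon. Going by the values given here, the closest precedent is an at least 2.3-fold higher number from compound 2 to compound 3 (0.36 log units; beyond the scatter), in which 2-methoxyphenyl also gave way to a ring with 0 hydrogen-bond acceptors, so a modest rise in number, possibly to the limit, is expected for compound 4, a 2.1-fold higher number from compound 2 to compound 4 (0.32 log units; beyond the scatter). Compound 4 is estimated at 9000 nM in this assay, with a range of 4000 nM to 20000 nM.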

Compound 4, half-maximal inhibitory concentration: 9250 nM
For compound 4 the middle estimate is 1.0-fold (0.01 log units) below the measured one, and the stated range covers the measured number.
By their numbers in this assay, from the lowest: compounds 2, 1 and 4 (each within the scatter of the next, the first and the last beyond it). At a limit, above all of these: compound 3.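

In this assay, this position now gives a measured number, not a limit, for a ring with no hydrogen-bond acceptors in place of 2-methoxyphenyl: a 2.1-fold higher number from compound 2 to compound 4 (0.33 log units; beyond the scatter). 2,3-Dimethylphenyl and 4-ethoxyphenyl are not separated, with a 1.1-fold higher number from compound 1 to compound 4 (0.03 log units; within the scatter). The step of an at least 1.0-fold lower number from compound 3 to compound 4 (0.03 log units; that floor lies within the scatter) gives only a floor and settles no order. Compound 3 stands at a limit: the limit of > 10000 nM in this assay, at which 1 of the 4 values shown sits.

Going by these compounds, it remains open whether a ring carrying an amine, a carboxylic acid or a longer alkoxy chain at this position would bring the number below that of compound 2.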